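Sulfonamide series: ring swap from compound 3 to compound 4

A few compounds are considered here, and "the series" means these few. Any claim that something is new, unique, unknown or untested is made for them only; others in the source may bear on it.

Compound 3 `O=S(=O)(Nc1ccc2oc(-c3ccccc3)nc2c1)c1ccccc1O` carries a 2-hydroxyphenyl on the sulfonyl sulfur. In an assay on isolated protein for inhibition of malate dehydrogenase, mitochondrial (Sus scrofa), with stated times of 45 min and 30 min (on this read-out higher numbers stand for weaker inhibition and lower numbers for stronger inhibition), compound 3 gives only a limit, > 63000 nM. Compound 1 `O=S(=O)(Nc1ccc2oc(-c3ccccc3)nc2c1)c1ccccc1Cl` in this assay also gives a limit, > 63000 nM. Compound 2 `COc1ccccc1S(=O)(=O)Nc1ccc2oc(-c3ccccc3)nc2c1` in this assay likewise gives a limit, > 63000 nM. All three sit at the limit of > 63000 nM in this assay, at which 3 of the 3 values shown sit, so the steps a step that the two limits leave unreadable from compound 1 to compound 2, a step that the two limits leave unreadable from compound 1 to compound 3 and a step that the two limits leave unreadable from compound 2 to compound 3 remain unreadable; whether chloro, methoxy or hydroxy on the aromatic carbon alters anything cannot be told from these numbers.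

Compound 4 `Cc1cccc(S(=O)(=O)Nc2ccc3oc(-c4ccccc4)nc3c2)c1` differs from compound 3 by 3-methylphenyl in place of 2-hydroxyphenyl on a sulfonyl sulfur. Within the data shown here, no measured step gives a readable size for a change of this kind, and the three unreadable steps leave the direction open. With every shown value at the limit, the expectation for the step that the limit leaves unreadable from compound 3 to compound 4 in this assay is that compound 4 stays outside the readable range rather than showing a step beyond the scatter. Compound 4 is therefore expected to give about 80000 nM in this assay, with a range from 25000 nM to 250000 nM, most probably again reported only as a limit.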

Compound 4, half-maximal inhibitory concentration: > 63000 nM
Compound 4: only a limit was reported; the forecaster's own chance of this, stated with the estimate: 80%; the middle value lies beyond the limit too.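

In this assay compound 4 gives only a limit, > 63000 nM, so its steps from compound 1, compound 2 and compound 3 cannot be read. Whether the groups on the sulfonyl sulfur differ at all in inhibition stays open: the limit of > 63000 nM in this assay, at which 4 of the 4 values shown sit.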